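Benzyl ring halogen swap from compound 3 to compound 4

A few compounds are considered here, and "the series" means these few. Any claim that something is new, unique, unknown or untested is made for them only; others in the source may bear on it.

Three compounds of the series carry a measurement. Compound 1 `O=C(O)c1nn(Cc2cc(Br)ccc2OCc2ccccc2)cc1F` gives 123 nM in an assay on CHO-K1 cells for displacement of a labelled ligand from prostaglandin E2 receptor EP1 subtype (Homo sapiens); on this read-out higher numbers stand for weaker inhibition and lower numbers for stronger inhibition. Going by the values given here, compound 2 `Cc1cn(Cc2cc(Br)ccc2OCc2ccccc2)nc1C(=O)O` gives 427 nM in this assay; the only single-point step among the measured set, a 3.5-fold higher number from compound 1 to compound 2 (0.54 log units; beyond the scatter), is a methyl in place of fluoro on an aromatic carbon of the shared core. Compound 3 `Cc1cc(C(=O)O)nn1Cc1cc(Br)ccc1OCc1ccc(F)cc1F` gives 0.525 nM and stands lowest of the three, beyond the scatter from both compound 1 and compound 2, so it is the most potent compound measured here.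

Compound 4 `Cc1cc(C(=O)O)nn1Cc1cc(Br)ccc1OCc1ccccc1Cl` has not been measured. It differs from compound 3 in one place: 2-chlorophenyl in place of 2,4-difluorophenyl on a saturated chain carbon bound to an oxygen on an aromatic ring. Among the compounds with values here, no measured step touches this benzyl ring; the step from compound 1 to compound 2 concerns a different position, and compounds 1 and 2 carry an unsubstituted benzyl but differ from compound 3 elsewhere as well, so their values show only that the series spans a wide range in this assay. With a chlorine on the entering ring and two fluorines given up, a change no larger than the scatter, or at most a small loss, is expected, written as a 1.7-fold higher number from compound 3 to compound 4 (0.23 log units; within the scatter). Compound 4 is therefore expected at 0.9 nM, between 0.2 nM and 4 nM.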

Compound 4, half-maximal inhibitory concentration: 3.16 nM
The estimate for compound 4 lay 3.5-fold (0.55 log units) below the measured number; the range from low to high includes it.
By their numbers in this assay, from the lowest: compound 3; then compound 4; then compound 1; then compound 2.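

In this assay, going by these compounds alone, the step from 2,4-difluorophenyl to 2-chlorophenyl on a saturated chain carbon bound to an oxygen on an aromatic ring gives a 6.0-fold higher number from compound 3 to compound 4 (0.78 log units; beyond the scatter), the first direct reading at this position, since the only earlier step concerned a methyl in place of fluoro at a different place on the shared core. The step lies beyond the scatter, so the substituents on this ring do register in the read-out, yet it is modest in size, and compound 4 at 3.16 nM shows that this ring can carry a chlorine and lose both fluorines with only that partial loss. The compounds shown offer no measurement that would account for the direction or the size of this step.

Two fluorines leave and one chlorine enters in a single step, so the contribution of each halogen cannot be separated, and the unsubstituted benzyl has no reading on the core of compound 3. On these data alone, how this ring responds to a trifluoromethyl, a methoxy or a nitrile also remains open.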